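A few compounds are considered here, and "the series" means these few. Any claim that something is new, unique, unknown or untested is made for them only; others in the source may bear on it.

Of the compounds shown here, three with a shared core have been measured in a functional assay on A549 cells (Homo sapiens) for antiproliferative activity, with a stated time of 72 h, tested at 50 ug/mL; a lower number here means a weaker effect, a higher number a stronger effect of the compound at the concentration tested. Compound 1 `COc1ccc(N2CCn3c2n[nH]c(=O)c3=O)cc1` gives 0% in this assay, compound 2 `O=c1[nH]nc2n(c1=O)CCN2c1ccc(Cl)cc1` gives 15%, and compound 3 `N=c1c(=O)[nH]nc2n1CCN2c1ccc(Cl)cc1` gives 27%. Compound 3 therefore stands highest of the three, with compound 2 its nearest neighbour below it and compound 1 furthest below, both gaps being beyond the scatter. Among the compounds with values here, the one single-point step among the measured compounds is a number 15 percentage points higher from compound 1 to compound 2 (beyond the scatter), a modest rise.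

Compound 4 `N=c1c(=O)[nH]nc2n1CCN2c1ccccc1` is the next compound to be measured in this assay. It differs from compound 3 in one place: hydrogen in place of chloro on an aromatic carbon, on an aromatic carbon of a six-membered aromatic ring of carbon only, para to a large group. Within the data shown here, no measured pair shows chloro replaced by hydrogen at this position. Among the measured compounds shown here, the only step that bears on it is the one from compound 1 to compound 2, where chloro arriving in place of methoxy raised the number modestly; compound 4 now loses that chloro. A modest fall is therefore expected, so compound 4 is estimated at 15%, within 0% to 30%, which would mean an expected step of a number 12 percentage points lower from compound 3 to compound 4 (beyond the scatter).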

Compound 4, a percentage reported as inhibition, at one concentration (the size of the read-out at that concentration, not a potency): 38%
The estimate for compound 4 lay 23 percentage points below the measured number, and the stated range ends below it.
By their numbers in this assay, from the lowest: compound 1; then compound 2; then compound 3; then compound 4.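

In this assay, hydrogen in place of chloro on this aromatic carbon, para to a large group, gives a number 11 percentage points higher from compound 3 to compound 4 (beyond the scatter) and puts compound 4 highest of the four compounds, with no substituent at this position at all. The earlier step, a number 15 percentage points higher from compound 1 to compound 2 (beyond the scatter) with chloro in place of methoxy, could be read as a gain from chloro, but the new pair shows that chloro is not required here and that, on the core of compound 3, the number is higher without it; the two steps come from different cores, so they do not give one ranking of methoxy, chloro and hydrogen across the series. Nothing in the data shown accounts for this rise, and the read-out at a single concentration gives no potency.

The compounds shown leave open whether hydrogen would also stand above chloro on the core of compound 2, and where methoxy would fall on the core of compound 4. They also leave open how a fluoro group, an amine or a carboxylic acid on this same carbon would compare with hydrogen.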